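Series notes: removing the ethyl group, cytotoxicity outlook

This account rests on a few compounds, and the source may have more. Where it says the series, first, only, none or still open, it means among the compounds named here.

The series shares one core, carried on compound 1 `CCc1csc(CN[C@@H]2C[C@H]3C[C@@H]([C@H]2C)C3(C)C)c1`. In an ADME assay on MDCK cells (Canis lupus familiaris) for cytotoxicity, read by microscopy, with a stated time of 48 h (on this read-out lower numbers stand for higher toxicity in this test and higher numbers for lower toxicity in this test), compound 1 gives 25000 nM. Compound 2 `C[C@H]1[C@H](NCc2ccc(Cl)s2)C[C@H]2C[C@@H]1C2(C)C` gives 25000 nM in this assay, level with compound 1 at the digits recorded and within the scatter of it. Compound 3 `C[C@H]1[C@H](NCc2sccc2-c2ccccc2)C[C@H]2C[C@@H]1C2(C)C` gives 12500 nM in this assay. Compound 1 thus stands with compound 2 at the top of the three numbers, its nearest neighbour being compound 2 with no change at the digits recorded, and its furthest being compound 3, yet that gap also lies within the scatter, so no order among the three can be read from these values. Among the measured compounds shown here, no two measured compounds differ in only one place, so no single-change step between measured compounds is available.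

Compound 4 `C[C@H]1[C@H](NCc2cccs2)C[C@H]2C[C@@H]1C2(C)C` differs from compound 1 in one place: hydrogen in place of ethyl on an aromatic carbon. Compounds 1, 2 and 3 carry different groups on the same ring and all sit within the scatter of each other, which gives no sign that the group at that position moves the read-out. No movement beyond the scatter is expected in either direction, so the expected step is no change at the digits printed from compound 1 to compound 4 (within the scatter). For compound 4 the estimate in this assay is 25000 nM, with a range from 12500 nM to 50000 nM.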

Compound 4, minimum cytotoxic concentration: 25000 nM
The estimate for compound 4 equals the measured number at the digits printed; measured number inside the range.
By their numbers in this assay, from the lowest: compounds 3, 1, 2 and 4 (each within the scatter of the next).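

With compound 4 the series gains its first single-change steps, so the effect of a group on the aromatic ring can be read directly rather than inferred from compounds that differ in more than one place. In this assay, hydrogen in place of ethyl gives no change at the digits printed from compound 1 to compound 4 (within the scatter), hydrogen in place of chloro gives no change at the digits printed from compound 2 to compound 4 (within the scatter), and hydrogen in place of phenyl gives a 2.0-fold higher number from compound 3 to compound 4 (0.30 log units; within the scatter), so none of these three groups on an aromatic carbon can be told apart from hydrogen in this test. No measurement bears on why the read-out stays within the scatter across these changes, and the notes offer no explanation for it.

From the compounds shown here alone, it remains open whether a group of another kind on this aromatic carbon, such as an amine, a carboxylic acid or a longer alkyl chain, would move the read-out beyond the scatter. Among the compounds shown here, also open is whether a change away from the aromatic ring, in the shared core of compound 1, would do so, since every step so far concerns a group on an aromatic carbon.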